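Imidazole in place of isoquinoline on the amide carbonyl

A few compounds are considered here, and "the series" means these few. Any claim that something is new, unique, unknown or untested is made for them only; others in the source may bear on it.

Three measured compounds share a core and an amide carbonyl. Compound 1 `CCn1nc(C)cc1C(=O)Nc1nc2cc(C(N)=O)cc(OC)c2n1CCCNC(=O)OCc1ccccc1` gives only a limit in an assay for activation of interferon regulatory factor 3 (Homo sapiens), read by a luciferase reporter, with a stated time of 20 h (on this read-out higher numbers stand for an effect only at larger amounts of compound and lower numbers for an effect already at smaller amounts), > 100000 nM. Compound 2 `CCCn1c(NC(=O)c2cc(C)nn2CC)nc2cccc(OC)c21` also gives a limit in this assay, > 100000 nM. Compound 3 `CCCn1c(NC(=O)c2nccc3ccccc23)nc2cc(C(N)=O)cc(OC)c21` likewise reaches only a limit in this assay, > 100000 nM. Among the measured compounds shown here, compound 3 therefore stands where all three values sit, at the limit of > 100000 nM in this assay, at which 3 of the 3 values shown sit, and none of them is a number, so no measured step between them exists. Compound 4 `CCCn1c(NC(=O)c2cncn2C)nc2cc(C(N)=O)cc(OC)c21` differs from compound 3 by 1-methyl-1H-imidazol-5-yl in place of isoquinolin-1-yl on a carbonyl carbon. With every value a limit, no direction can be supported from the data. The expected step is a number no higher from compound 3 to compound 4 (the limit leaves the size open), no larger than the scatter. Compound 4 is estimated at 100000 nM, with a range from 10000 nM to 300000 nM.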

Compound 4, half-maximal effective concentration: > 100000 nM
Compound 4: no number, only a limit (the forecaster's own chance of this, stated with the estimate: 75%); the middle value sits exactly at the limit.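

Compound 3 and compound 4 both give only a limit, and no step can be read between them. The compounds shown leave open which group on the carbonyl carbon, if any, would give a measurable number in this assay.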